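A New End Group on a Series at the Limit

The source may hold more compounds than are shown below. What is called first, only, known or untested is meant among the compounds shown, and "the series" means these compounds.

Values in a functional assay on HT-29 cells (Homo sapiens) for inhibition, read by sulforhodamine B assay (a higher number here means a weaker inhibitor, a lower number a stronger inhibitor), each one a limit and not a number:
- Compound 1 `COC(=O)CC/C(C)=C/Cc1c(OC)c(C)c2c(c1OCC#CCN1CCN(c3ccc(C#N)cc3)CC1)C(=O)OC2` gives > 50000 nM as its limit
- Compound 2 `COC(=O)CC/C(C)=C/Cc1c(OC)c(C)c2c(c1OCC#CCN1CCN(c3ccc(O)cc3)CC1)C(=O)OC2` gives > 50000 nM as its limit
- Compound 3 `COC(=O)CC/C(C)=C/Cc1c(OC)c(C)c2c(c1OCC#CCN1CCCc3ccccc31)C(=O)OC2` gives > 50000 nM as its limit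

Compound 3 has no exact potency on these numbers, and it stands with the rest of the set: the limit of > 50000 nM in this assay, at which 3 of the 3 values shown sit, sums up the picture so far.

Compound 4 `CCCCNc1ccc(CC#CCOc2c(C/C=C(\C)CCC(=O)OC)c(OC)c(C)c3c2C(=O)OC3)cc1` has not yet been measured. Its structure departs from that of compound 3 in one place: 4-(butylamino)phenyl in place of 1,2,3,4-tetrahydroquinolin-1-yl on a saturated chain carbon bound to a triple-bonded carbon describes the exchange at the end of the chain.

Going by the values given here, only one measured step exists, and it concerns a different group: a step that the two limits leave unreadable from compound 1 to compound 2 gives no size to carry over. Among the compounds with values here, the only remaining guide is compound 3 at > 50000 nM, again a limit, so compound 4 is expected to stay close to that level. The expected change, a number no higher from compound 3 to compound 4 (the limit leaves the size open), is an estimate with no firm direction. For compound 4 the estimated value is 50000 nM, with an expected range from 15000 nM to 100000 nM in this assay, and a report of only a limit is the likeliest outcome.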

Compound 4, half-maximal inhibitory concentration: 36700 nM
For compound 4 the middle estimate is 1.4-fold (0.13 log units) above the measured one; measured number inside the range.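

Going by these compounds alone, at this position, on a saturated chain carbon bound to a triple-bonded carbon, exchanging 1,2,3,4-tetrahydroquinolin-1-yl for 4-(butylamino)phenyl gives the only exact number in the set in this assay. Within the data shown here, the change reads as an at least 1.3-fold lower number from compound 3 to compound 4 (0.13 log units; that floor lies within the scatter), and because this is only a floor, the true step could be larger or could be no real step at all. The exact number for compound 4 is therefore a single reading in a set that otherwise gives only limits: the limit of > 50000 nM in this assay, at which 3 of the 4 values shown sit.

The compounds shown leave open which part of the new end group matters: the aromatic ring, the amine hydrogen or the butyl chain. An unsubstituted amino group, an octylamino chain or a carboxylic acid in place of the butylamino group would help to separate these parts.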